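The source may hold more compounds than are shown below. What is called first, only, known or untested is meant among the compounds shown, and "the series" means these compounds.

Measured in a functional assay on KYSE-70 cells for antiproliferative activity against KYSE-70 cell line (Homo sapiens), read by MTT assay, with a stated time of 72 h; a higher number here means a weaker inhibitor, a lower number a stronger inhibitor:
- compound 1 `CC(C)(C)c1ccc(-c2ccc3c(C(=O)Nc4cccc(F)c4)cc(=O)[nH]c3c2)cc1`: > 20000 nM
- compound 2 `O=C(Nc1cccc(F)c1)c1cc(=O)[nH]c2cc(-c3ccncc3)ccc12`: > 20000 nM
- compound 3 `Cc1cc(-c2ccc3c(C(=O)Nc4cccc(F)c4)cc(=O)[nH]c3c2)c(C)cc1F`: > 20000 nM

All three entries are limits of the assay, not numbers.

Compound 3 gives > 20000 nM, which is a limit. Among the measured compounds shown here, the series so far sits together: the limit of > 20000 nM in this assay, at which 3 of the 3 values shown sit.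

The next compound is compound 4 `O=C(Nc1cccc(F)c1)c1cc(=O)[nH]c2cc(-c3ccc(F)c(CO)c3)ccc12`, with 4-fluoro-3-(hydroxymethyl)phenyl in place of 4-fluoro-2,5-dimethylphenyl on an aromatic carbon.

Three measured steps exchange a group at this same place: a step that the two limits leave unreadable from compound 1 to compound 2, a step that the two limits leave unreadable from compound 1 to compound 3 and a step that the two limits leave unreadable from compound 2 to compound 3. None of them has a readable size, so they give no direction and no size for the new exchange. In this assay, no step beyond the scatter is therefore expected, and a further limit is the likeliest report.

The expected change is a number no higher from compound 3 to compound 4 (the limit leaves the size open).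

For compound 4 the estimate is 20000 nM, with an expected range from 7000 nM to 40000 nM.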

Compound 4, half-maximal inhibitory concentration: > 20000 nM
Compound 4 ended at the assay's limit (the forecaster's own chance of this, stated with the estimate: 75%); the middle value sits exactly at the limit.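

In this assay compound 4 gives > 20000 nM, which is a limit and not a number. Among the compounds shown here, no step among compound 1, compound 2, compound 3 and compound 4 can be read. The compounds shown leave open how any exchange at this place changes activity, with the series resting at one value: the limit of > 20000 nM in this assay, at which 4 of the 4 values shown sit.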